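A Glycolamide Replaces the Imidazole Carboxamide

The compounds below may be only part of what the source reports. "The series", "measured", "known", "first", "only" and "open" are said of these compounds alone.

Of the compounds shown here, three have been measured in an assay on isolated protein for displacement of a labelled ligand from 5-hydroxytryptamine receptor 6 (Homo sapiens); a higher number here means a weaker inhibitor, a lower number a stronger inhibitor. Compound 1 `CC(=N)NCC1CCCc2cc(S(=O)(=O)c3ccccc3)ccc21` gives 0.631 nM; compound 2 `NC[C@@H]1CCCc2cc(S(=O)(=O)Cc3ccccc3)ccc21` gives 158 nM; and compound 3 `O=C(NC[C@@H]1CCCc2cc(S(=O)(=O)c3cccc(F)c3)ccc21)c1ncc[nH]1` gives 15.9 nM. Compound 3 thus stands second of the three, with compound 2 nearest to it and compound 1 furthest from it, both gaps lying beyond the scatter. Compound 4 `O=C(CO)NC[C@@H]1CCCc2cc(S(=O)(=O)c3cccc(F)c3)ccc21` has not yet been measured. It differs from compound 3 in one place (hydroxymethyl in place of 1H-imidazol-2-yl on a carbonyl carbon), the exchange sitting on a carbonyl carbon whose other neighbour is an amide-type nitrogen. Among the compounds with values here, no measured pair shows this particular exchange, so the size of the step is uncertain. Within the data shown here, since compound 3 gives 15.9 nM and no measured compound carries the hydroxymethyl group, the expectation is a modest loss, a 2.5-fold higher number from compound 3 to compound 4 (0.40 log units; beyond the scatter), a step that may or may not exceed the scatter. Compound 4 is therefore estimated at 40 nM, within a range from 10 nM to 160 nM.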

Compound 4, inhibition constant: 0.1 nM
Compound 4: middle estimate off by 400-fold (2.60 log units), on the high side, outside the stated range (below it).
By their numbers in this assay, from the lowest: compound 4; then compound 1; then compound 3; then compound 2.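

In this assay, the exchange on the carbonyl carbon gives a 160-fold lower number from compound 3 to compound 4 (2.20 log units; beyond the scatter) and so shows that this position, whose other neighbour is an amide-type nitrogen, responds strongly to what stands on it. The earlier compounds shown here could not show this, as no two of them differed in one place. Here 1H-imidazol-2-yl, with its 5 heavy atoms and one ring, gives way to hydroxymethyl, with 2 heavy atoms and no ring, while the counts of hydrogen-bond donors and acceptors stay the same, and nothing at hand accounts for the size of the step.

The compounds shown leave open whether the hydroxyl of the hydroxymethyl group matters, since no methyl or aminomethyl group stands on this carbonyl carbon. They also leave open how a longer chain, such as hydroxyethyl, would fare in the same place.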